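Ring-bound dimethylamino on the shared coumarin-glycoside core

The source may hold more compounds than are shown below. What is called first, only, known or untested is meant among the compounds shown, and "the series" means these compounds.

Measured compounds:
Compound 1, `CO[C@@H]1[C@@H](OC(=O)c2ccc(C)[nH]2)[C@@H](O)[C@H](Oc2ccc3c(N4CCNCC4)cc(=O)oc3c2C)OC1(C)C`: 8.3
Compound 2, `CCN1CCN(c2cc(=O)oc3c(C)c(O[C@@H]4OC(C)(C)[C@H](OC)[C@@H](OC(=O)c5ccc(C)[nH]5)[C@H]4O)ccc23)CC1`: 7.5
Compound 3, `CO[C@@H]1[C@@H](OC(=O)c2ccc(C)[nH]2)[C@@H](O)[C@H](Oc2ccc3c(N(C)CCN(C)C)cc(=O)oc3c2C)OC1(C)C`: 8.2

Of the compounds shown here, three on one shared core have been measured in a physicochemical assay for acid dissociation. Compound 3 stands second highest of the three numbers; its nearest neighbour is compound 1, which is a number 0.10 log units lower from compound 1 to compound 3 (within the scatter), while compound 2 lies furthest off, as a number 0.70 log units higher from compound 2 to compound 3 (beyond the scatter) shows. Among the measured compounds shown here, the only step beyond the scatter among the three runs from compound 1 to compound 2, a number 0.80 log units lower from compound 1 to compound 2 (beyond the scatter).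

Compound 4, `CO[C@@H]1[C@@H](OC(=O)c2ccc(C)[nH]2)[C@@H](O)[C@H](Oc2ccc3c(N4CCC(N(C)C)CC4)cc(=O)oc3c2C)OC1(C)C`, has not been measured. It differs from compound 3 at one place: 4-(dimethylamino)piperidin-1-yl in place of (2-(dimethylamino)ethyl)(methyl)amino on an aromatic carbon. Both compound 3 and compound 4 keep two nitrogens and no donor in this group, and compound 3 itself sits close to compound 1 in this assay. For the measured compounds named here, no measured step replaces an open chain by a ring of this kind, so the evidence is indirect; the steps that exist show moves of modest size or none at all. A step of modest size or smaller is therefore expected, most likely upward, as a number 0.40 log units higher from compound 3 to compound 4 (beyond the scatter). Compound 4 is estimated to give 8.6 in this assay, with a range from 8 to 9.2.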

Compound 4, acid dissociation constant: 9
Compound 4: middle estimate off by 0.40 log units, on the low side, within the range that was stated.
By their numbers in this assay, from the lowest: compound 2; then compounds 3 and 1 (each within the scatter of the next); then compound 4.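

In this assay the 4-(dimethylamino)piperidin-1-yl group on this aromatic carbon sets a compound apart from both compounds that had stayed within the scatter of each other, with a number 0.70 log units higher from compound 1 to compound 4 (beyond the scatter) and a number 0.80 log units higher from compound 3 to compound 4 (beyond the scatter) on the same scale. Among the compounds shown here, the range reachable at this position also proves wider than the earlier compounds showed, since the largest step so far is a number 1.50 log units higher from compound 2 to compound 4 (beyond the scatter) and it places compound 4 highest of the four. The step from the open chain to the ring arises with the counts of hydrogen-bond donors and acceptors in the group unchanged, so these counts alone do not fix the number at this position, and no measurement shown explains the shift.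

On these data alone, it remains open whether a longer chain between the two nitrogens of the open group would move the number as the ring does. Also open, as far as these compounds go, is how a 3-(dimethylamino)pyrrolidin-1-yl group or a 4-aminopiperidin-1-yl group with its plain primary amine would stand in this assay against compound 4 on the shared core.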